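A few compounds are considered here, and "the series" means these few. Any claim that something is new, unique, unknown or untested is made for them only; others in the source may bear on it.

Measured so far in a functional assay on MCF7 cells (Homo sapiens) for cytotoxicity, read by MTT assay, with a stated time of 72 h; on this read-out higher numbers stand for weaker inhibition and lower numbers for stronger inhibition:
- Compound 1 `N[C@H]1CC[C@H](Nc2c(C(=O)NCc3ccc(Cl)cc3Cl)nc(Br)c3cccnc23)CC1`: "not determined" (no result reported)
- Compound 2 `COC(=O)c1nc(Br)c2cccnc2c1N[C@H]1CC[C@H](N)CC1`: > 20000 nM

Within the data shown here, compound 1 has no result, so compound 2 supplies the only reading on this scale. Compound 2 stands at > 20000 nM, which is a limit of the assay and not a number. This gives a single reference point: the limit of > 20000 nM in this assay, at which 1 of the 2 values shown sits.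

The next compound is compound 3 `N[C@H]1CC[C@H](Nc2c(C(=O)NCc3ccccn3)nc(Br)c3cccnc23)CC1`, which keeps the shared core of compound 2. The change is ((pyridin-2-yl)methyl)amino in place of methoxy on a carbonyl carbon.

Among the measured compounds shown here, no step between measured compounds is available to show how large such a change might be, so any expectation is a cautious one. A modest move toward stronger inhibition is expected, and it rests on compound 2 and its limit of > 20000 nM. Compound 3 could also turn out to be reported only as a limit in this assay.

The estimated change is an at least 2.2-fold lower number from compound 2 to compound 3 (0.34 log units; beyond the scatter). For compound 3 the estimate is 9000 nM, with an expected range of 2500 nM to 20000 nM.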

Compound 3, half-maximal inhibitory concentration: 15000 nM
Estimate against measurement, compound 3: 1.7-fold (0.22 log units) below; the range from low to high includes it.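

In this assay compound 3 gives 15000 nM, the only single number among the compounds shown, so ((pyridin-2-yl)methyl)amino on this carbonyl carbon yields a cytotoxicity value that can be read on the scale. The change is stated as an at least 1.3-fold lower number from compound 2 to compound 3 (0.12 log units; that floor lies within the scatter), which means that it is known only as a floor and does not establish a real gain on its own. Compound 2 can anchor the step only through its limit, which is not a number: the limit of > 20000 nM in this assay, at which 1 of the 3 values shown sits.

As far as these compounds go, the true size of the change therefore stays open, and compound 1, with a different group on the same carbonyl carbon, adds no reading that could show whether the aromatic ring matters. Also open, from the compounds shown here alone, is how a small methylamino group, or a hydroxy group that would make a carboxylic acid, would read on this carbonyl carbon in this assay, and whether a longer chain between the amide nitrogen and the pyridine ring would move the number.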